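The compounds below may be only part of what the source reports. "The series", "measured", "known", "first", "only" and "open" are said of these compounds alone.

Measured in a functional assay for agonist activity at G protein-coupled receptor 88 (Homo sapiens), read by HTRF and cAMP accumulation; on this read-out higher numbers stand for an effect only at larger amounts of compound and lower numbers for an effect already at smaller amounts:
Compound 1 `CC[C@H](C)[C@H](N)CN(C(=O)[C@@H]1C[C@H]1c1cccc(OC)c1)c1ccc(-c2ccccc2)cc1` gives 3000 nM.
Compound 2 `CC[C@H](C)[C@H](N)CN(C(=O)[C@@H]1C[C@H]1C1CCCCC1)c1ccc(-c2ccccc2)cc1` reaches only a limit, > 25000 nM.
Compound 3 `CC[C@H](C)[C@H](N)CN(C(=O)[C@@H]1C[C@H]1c1ccccn1)c1ccc(-c2ccccc2)cc1` gives 130 nM.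

Compound 3 holds the lowest of the two numbers; its nearest neighbour is compound 1, separated by a 23-fold lower number from compound 1 to compound 3 (1.36 log units; beyond the scatter). Compound 2 sits at a limit, (the limit of > 25000 nM in this assay, at which 1 of the 3 values shown sits). Compound 4 `CC[C@H](C)[C@H](N)CN(C(=O)[C@@H]1C[C@H]1c1ccsc1)c1ccc(-c2ccccc2)cc1` differs from compound 3 by thiophen-3-yl in place of pyridin-2-yl on a saturated ring carbon. Two measured steps change the group on this same saturated ring carbon and bear on it: a 23-fold lower number from compound 1 to compound 3 (1.36 log units; beyond the scatter) and an at least 190-fold lower number from compound 2 to compound 3 (2.28 log units; beyond the scatter), both large, and an at least 8.3-fold higher number from compound 1 to compound 2 (0.92 log units; beyond the scatter), at least modest. Pyridin-2-yl thus gave the best number of the three groups tried, and leaving it for thiophen-3-yl is expected to cost, with a 7.7-fold higher number from compound 3 to compound 4 (0.89 log units; beyond the scatter) in this assay. Compound 4 is therefore estimated at 1000 nM, between 250 nM and 5000 nM.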

Compound 4, half-maximal effective concentration: 450 nM
The estimate for compound 4 lay 2.2-fold (0.35 log units) above the measured number; measured number inside the range.
By their numbers in this assay, from the lowest: compound 3; then compound 4; then compound 1. At a limit, above all of these: compound 2.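

Thiophen-3-yl shows that a five-membered aromatic ring carrying sulfur also works on this saturated ring carbon, with a 6.7-fold lower number from compound 1 to compound 4 (0.82 log units; beyond the scatter), although pyridin-2-yl keeps its lead, with a 3.5-fold higher number from compound 3 to compound 4 (0.54 log units; beyond the scatter). Replacing cyclohexyl gives an at least 55-fold lower number from compound 2 to compound 4 (1.74 log units; beyond the scatter). That step rests on a limit of the assay for compound 2: the limit of > 25000 nM in this assay, at which 1 of the 4 values shown sits.

The change alters ring size and hetero atom at once, and the compounds shown do not separate the two. As far as these compounds go, how unsubstituted phenyl, pyridin-3-yl or thiophen-2-yl would read on this carbon remains open.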